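From Isobutyl to 2-Ethylphenyl on the Saturated Ring Carbon

A few compounds are considered here, and "the series" means these few. Any claim that something is new, unique, unknown or untested is made for them only; others in the source may bear on it.

Measured compounds:
compound 1 `CN1C(=O)C(CC2CC2)N(C)c2nc(Nc3ccc(S(N)(=O)=O)cc3)ncc21` gives 211 nM
compound 2 `CC(C)CC1C(=O)N(C)c2cnc(Nc3ccc(S(N)(=O)=O)cc3)nc2N1C` gives 77 nM

In an assay on Sf9 cells for inhibition of serine/threonine-protein kinase 4 (Homo sapiens), read by luminescence and ADP-Glo, with a stated time of 1 h, in the presence of a further agent that is not named here (a higher number here means a weaker inhibitor, a lower number a stronger inhibitor), compound 2 stands lowest of the two numbers, with compound 1 the nearest, and the step of a 2.7-fold lower number from compound 1 to compound 2 (0.44 log units; beyond the scatter) is modest. Compound 3 `CCc1ccccc1C1C(=O)N(C)c2cnc(Nc3ccc(S(N)(=O)=O)cc3)nc2N1C` carries the change (2-ethylphenyl in place of isobutyl on a saturated ring carbon). Going by the values given here, the only measured step swaps one saturated chain group for another, so it bears only loosely on an aromatic group entering here, and there is no measured case of an aryl group at this ring carbon. Compound 3 is therefore expected near 130 nM, between 25 nM and 700 nM, a step of a 1.7-fold higher number from compound 2 to compound 3 (0.23 log units; within the scatter) that is uncertain in direction.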

Compound 3, half-maximal inhibitory concentration: 51 nM
Estimate against measurement, compound 3: 2.5-fold (0.41 log units) above, within the range that was stated.
By their numbers in this assay, from the lowest: compounds 3 and 2 (each within the scatter of the next); then compound 1.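

In this assay, the saturated ring carbon accepts an aromatic group: replacing isobutyl, with its 4 heavy atoms, by 2-ethylphenyl, with its 8, gives a 1.5-fold lower number from compound 2 to compound 3 (0.18 log units; within the scatter) and leaves the two groups indistinguishable here. Replacing cyclopropylmethyl by the same group gives a 4.1-fold lower number from compound 1 to compound 3 (0.62 log units; beyond the scatter) and so stays beyond the scatter. Nothing given here bears on the reason for either step. Going by these compounds, what remains open is what a phenyl without the ethyl group, a pyridyl ring or a chain ending in an amine would give at this ring carbon.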